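Combining methyl and chloro on the piperidine aryl group

A few compounds are considered here, and "the series" means these few. Any claim that something is new, unique, unknown or untested is made for them only; others in the source may bear on it.

Of the compounds shown here, three sharing one core have been measured in a functional assay for antagonist activity at transient receptor potential cation channel subfamily V member 1 (Homo sapiens), read by FLIPR and calcium flux; on this read-out lower numbers stand for stronger inhibition and higher numbers for weaker inhibition. Compound 1 `Cc1ccccc1N1CCC(C(=O)Nc2ccc3c(c2)NC(=O)CO3)CC1` gives 150 nM, compound 2 `O=C1COc2ccc(NC(=O)C3CCN(c4cccc(Cl)c4)CC3)cc2N1` gives 190 nM, and compound 3 `O=C1COc2ccc(NC(=O)C3CCN(c4cc(F)c(F)c(F)c4)CC3)cc2N1` gives 59 nM, the lowest of the three numbers. Compound 4 `Cc1c(Cl)cccc1N1CCC(C(=O)Nc2ccc3c(c2)NC(=O)CO3)CC1` has not yet been measured in this assay. It differs from compound 3 in one place: 3-chloro-2-methylphenyl in place of 3,4,5-trifluorophenyl on an amine nitrogen in a ring.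

Going by the values given here, two measured steps bear on this. The step of a 2.5-fold lower number from compound 1 to compound 3 (0.41 log units; beyond the scatter) and the step of a 3.2-fold lower number from compound 2 to compound 3 (0.51 log units; beyond the scatter) both show that moving away from the trifluorophenyl group to a single-substituted phenyl gives a higher number, while the step of a 1.3-fold higher number from compound 1 to compound 2 (0.10 log units; within the scatter) shows that methyl and chloro alone give similar numbers. Compound 4 carries both of those substituents, so it is expected to land between the numbers of compound 1 and compound 3, with the step of a 1.9-fold higher number from compound 3 to compound 4 (0.27 log units; within the scatter) expected to be a modest rise. Compound 4 is therefore estimated at 110 nM in this assay, with a likely range from 35 nM to 350 nM.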

Compound 4, half-maximal inhibitory concentration: 100 nM
Compound 4: middle estimate off by 1.1-fold (0.04 log units), on the high side; low and high end bracket the measured number.
By their numbers in this assay, from the lowest: compounds 3, 4, 1 and 2 (each within the scatter of the next, the first and the last beyond it).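

In this assay, methyl in place of hydrogen on an aromatic carbon gives a 1.9-fold lower number from compound 2 to compound 4 (0.28 log units; within the scatter), and chloro in place of hydrogen on an aromatic carbon gives a 1.5-fold lower number from compound 1 to compound 4 (0.18 log units; within the scatter), so neither single addition to the aryl group on the amine nitrogen moves the number beyond the scatter. Putting 3-chloro-2-methylphenyl in place of 3,4,5-trifluorophenyl gives a 1.7-fold higher number from compound 3 to compound 4 (0.23 log units; within the scatter), so this group, carrying both substituents, stays within the scatter of the trifluorophenyl group, which the two singly substituted phenyl groups did not. Nothing available bears on why these steps are as they are.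

Left open is whether a trifluoromethyl or methoxy group on this phenyl ring, or a pyridine ring in its place, would give a number beyond the scatter of compound 3. Going by these compounds, it also remains open whether methyl and chloro would give similar steps on a fluorinated phenyl ring.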